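Aryl sulfonyl change on a shared thiocarbamate-free core

A few compounds are considered here, and "the series" means these few. Any claim that something is new, unique, unknown or untested is made for them only; others in the source may bear on it.

Measured compounds:
Compound 1, `COc1ccc(OC)c(S(=O)(=O)NC2=NCCN2C(=S)SN2CCn3c2nsc3=S)c1`: >= 20000 nM
Compound 2, `O=S(=O)(NC1=NCCN1C(=S)SN1CCn2c1nsc2=S)c1cccc(OC(F)(F)F)c1`: >= 20000 nM

In a functional assay on KYSE-510 cells (Homo sapiens) for antiproliferative activity, read by crystal violet staining, with a stated time of 96 h (a lower number here means a stronger inhibitor of growth, a higher number a weaker inhibitor of growth), compound 1 gives >= 20000 nM, which is a limit of the assay and not a number. Compound 2 gives >= 20000 nM in this assay, again a limit. Both results sit at the limit of >= 20000 nM in this assay, at which 2 of the 2 values shown sit, so the two compounds cannot be ordered against each other; compound 1 stands at the weak end of what the assay reports, with no number of its own.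

Compound 3, `O=S(=O)(NC1=NCCN1C(=S)SN1CCn2c1nsc2=S)c1ccc(Cl)cc1`, has not been measured. It differs from compound 1 in 4-chlorophenyl in place of 2,5-dimethoxyphenyl on a sulfonyl sulfur. Among the compounds with values here, no step between measured compounds exists on which to size this change. With both known values at the limit, no movement beyond the scatter is expected, and the most probable outcome is another limit. Compound 3 is therefore estimated at 20000 nM, with a range of 8000 nM to 40000 nM, which corresponds to an expected step of a number no higher from compound 1 to compound 3 (the limit leaves the size open).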

Compound 3, concentration for 50% growth inhibition: >= 20000 nM
Compound 3: only a limit was reported; the forecaster's own chance of this, stated with the estimate: 70%; the middle value sits exactly at the limit.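

In this assay compound 3 gives >= 20000 nM, a limit of the assay and not a number. No step can be read between compound 1 and compound 3: the limit of >= 20000 nM in this assay, at which 3 of the 3 values shown sit. The compounds shown leave open whether any aryl group on the sulfonyl sulfur changes growth inhibition, with no compound here giving a number.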